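This account rests on a few compounds, and the source may have more. Where it says the series, first, only, none or still open, it means among the compounds named here.

Measured so far:
- compound 1, `COc1cc(/C=C/C(=O)/C=C(/C=C/c2ccc(OC(C)=O)c(OC)c2)NC2CCCCC2)ccc1OC(C)=O`: in an ADME assay on Caco-2 cells (Homo sapiens) for inhibition, read by MTT assay, with a stated time of 72 h (on this read-out lower numbers stand for stronger inhibition and higher numbers for weaker inhibition), compound 1 gives > 25000 nM, which is a limit of the assay and not a number.
- compound 2, `C=CCNC(=C\C(=O)/C=C/c1ccc(O)c(OC)c1)/C=C/c1ccc(O)c(OC)c1`: in this assay compound 2 gives > 25000 nM, again a limit rather than a number.

Compound 1 therefore stands at the edge of what this assay can report: the limit of > 25000 nM in this assay, at which 2 of the 2 values shown sit. Neither value shown is a true number, so nothing can be said about how compound 1 and compound 2 compare beyond the fact that both reach the limit.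

Compound 3, `CCC(C)NC(=C\C(=O)/C=C/c1ccc(OC(C)=O)c(OC)c1)/C=C/c1ccc(OC(C)=O)c(OC)c1`, keeps the core and both acetylated aromatic ends of compound 1 and changes only the group on the amine nitrogen: sec-butyl in place of cyclohexyl on an amine nitrogen. Within the data shown here, no measured pair with this kind of change is available, so the size of the step has to be judged from the two limits alone. Since every value shown sits at the limit, the step from compound 1 to compound 3 in this assay is expected to be none beyond the usual scatter, a step that the limit leaves unreadable from compound 1 to compound 3. Compound 3 is thus expected to give about 40000 nM, most likely reported again as a limit, within 20000 nM to 100000 nM.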

Compound 3, half-maximal inhibitory concentration: > 25000 nM
Compound 3 was reported as a limit; the forecaster's own chance of this, stated with the estimate: 80%; the middle value does not contradict the limit.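

In this assay compound 3 gives > 25000 nM, which is a limit and not a number. No step can be read between compound 1 and compound 3, as both stop at the same limit: the limit of > 25000 nM in this assay, at which 3 of the 3 values shown sit.

The compounds shown leave open whether any group on the amine nitrogen would give a true number in this assay.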